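Ring-amine aryl exchange: expectation for compound 3

This account rests on a few compounds, and the source may have more. Where it says the series, first, only, none or still open, it means among the compounds named here.

Compound 2 `Nc1scc(CN2CCN(c3ccc(F)cc3F)CC2)c1C(=O)c1ccc(Cl)cc1` gives 0% in a functional assay on CHO cells with adenosine receptor A1 (Homo sapiens) as the target, read by cAMP accumulation and immunoassay, with a stated time of 6 min, tested at 0.01 uM; on this read-out higher numbers stand for a weaker effect at the one concentration tested and lower numbers for a stronger effect. Compound 1 `Nc1scc(CN2CCN(C3CCCCCC3)CC2)c1C(=O)c1ccc(Cl)cc1` gives 2.9% in this assay. For the measured compounds named here, the only step available between measured compounds, a number 2.9 percentage points lower from compound 1 to compound 2 (within the scatter), lies within the scatter, so compound 2 and compound 1 cannot be told apart on this read-out; compound 2 stands at the near-zero end of two numbers that are indistinguishable.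

Compound 3 `Nc1scc(CN2CCN(c3ccc(F)c(Cl)c3)CC2)c1C(=O)c1ccc(Cl)cc1` is not yet measured. It differs from compound 2 in one place: 3-chloro-4-fluorophenyl in place of 2,4-difluorophenyl on an amine nitrogen in a ring. Going by the values given here, the single measured step that bears on this position is a number 2.9 percentage points lower from compound 1 to compound 2 (within the scatter), where a 2,4-difluorophenyl on the ring nitrogen in place of a cycloheptyl produced no change beyond the scatter. Nothing in the two measured compounds separates one substituent on the ring amine from another at the concentration tested.

Compound 3 is therefore expected to give about 2% in this assay, with a range from 0% to 10%. The step of a number 2 percentage points higher from compound 2 to compound 3 (within the scatter) is expected to be within the scatter, in no clear direction.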

Compound 3, a percentage reported as activity, at one concentration (the size of the read-out at that concentration, not a potency): 4.2%
For compound 3 the middle estimate is 2.2 percentage points below the measured one; low and high end bracket the measured number.
By their numbers in this assay, from the lowest: compounds 2, 1 and 3 (each within the scatter of the next).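

In this assay the exchange of the aryl group on the ring nitrogen gives a number 4.2 percentage points higher from compound 2 to compound 3 (within the scatter) and the exchange against the saturated ring gives a number 1.3 percentage points higher from compound 1 to compound 3 (within the scatter) so neither step separates the groups involved. For the compounds shown here, the earlier pair held only one aryl group against cycloheptyl, whereas this position now also holds a second halogen pattern, with chlorine entering in 3-chloro-4-fluorophenyl, and the read-out still does not tell the three groups on the ring nitrogen apart at the one concentration tested. No measurement offered here speaks to the reason for this flat picture.

The compounds shown leave open whether a group of another kind on this ring nitrogen, such as a benzyl, a chain ending in a carboxylic acid, or a plain hydrogen, would stay within the same narrow band of numbers. They also leave open whether cycloheptyl, 2,4-difluorophenyl and 3-chloro-4-fluorophenyl would separate in a full concentration series, since a single-concentration read-out near the floor gives no potency for any of them.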